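The compounds below may be only part of what the source reports. "The series", "measured", "known", "first", "only" and "open" are said of these compounds alone.

In an ADME assay on the whole organism (Rattus norvegicus, strain Fischer 344) for pharmacokinetics, at a dose of 3 mg/kg by the oral route (a higher number here means more compound in the circulation at the dose given, a lower number less compound in the circulation), three compounds that share one core have been measured at the same oral dose. Compound 1 `NC(=O)c1sc2nccc(N3CCC[C@H](COCC(=O)N4CCOCC4)C3)c2c1N` gives 501 nM, compound 2 `COC[C@H]1CCCN(c2ccnc3sc(C(N)=O)c(N)c23)C1` gives 251 nM, and compound 3 `Cc1noc(COC[C@H]2CCCN(c3ccnc4sc(C(N)=O)c(N)c34)C2)n1` gives 393 nM. The number for compound 3 therefore lies within the scatter of both of the others, and the three cannot be ranked with confidence.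

Compound 4 `Cn1ccnc1COC[C@H]1CCCN(c2ccnc3sc(C(N)=O)c(N)c23)C1` keeps the core and the chain and differs from compound 3 in a single group: 1-methyl-1H-imidazol-2-yl in place of 3-methyl-1,2,4-oxadiazol-5-yl on a saturated chain carbon bound to an oxygen on a saturated carbon. It carries 1-methyl-1H-imidazol-2-yl in place of 3-methyl-1,2,4-oxadiazol-5-yl, on a saturated chain carbon bound to an oxygen on a saturated carbon.

For the measured compounds named here, all the measured steps bear on this same place. They are a 2.0-fold lower number from compound 1 to compound 2 (0.30 log units; within the scatter), a 1.3-fold lower number from compound 1 to compound 3 (0.11 log units; within the scatter) and a 1.6-fold higher number from compound 2 to compound 3 (0.19 log units; within the scatter), and each stays within the scatter. Even the step to hydrogen, compound 2, does not leave it. Going by the values given here, no measured pair exchanges one five-membered aromatic ring for another, so the evidence is indirect and gives no direction. No change beyond the scatter is therefore expected in this assay. The expected step is a 1.1-fold lower number from compound 3 to compound 4 (0.05 log units; within the scatter), which is within the scatter. The estimated value for compound 4 is 350 nM, with an expected range from 150 nM to 800 nM.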

Compound 4, maximal plasma concentration: 37.7 nM
The estimate for compound 4 lay 9.3-fold (0.97 log units) above the measured number; the whole stated range lies above it.
By their numbers in this assay, from the lowest: compound 4; then compounds 2, 3 and 1 (each within the scatter of the next).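

In this assay, for the compounds shown here, the steps among the hydrogen, the (morpholin-4-yl)carbonyl and the 3-methyl-1,2,4-oxadiazol-5-yl had all stayed within the scatter, and 1-methyl-1H-imidazol-2-yl is the first group on this saturated chain carbon to go beyond it, with a 10-fold lower number from compound 3 to compound 4 (1.02 log units; beyond the scatter) and a 6.7-fold lower number from compound 2 to compound 4 (0.82 log units; beyond the scatter) and also a 13-fold lower number from compound 1 to compound 4 (1.12 log units; beyond the scatter) in the same direction. The position therefore does respond to the group it carries, and one five-membered aromatic ring cannot be exchanged for another of the same heavy-atom count without consequence here, even though the earlier groups, hydrogen among them, gave no sign of this. Nothing shown accounts for the step.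

The compounds shown leave open whether the drop belongs to the imidazole ring as such or to its methyl group, which an unmethylated 1H-imidazol-2-yl would separate, and whether other nitrogen rings, such as a pyridin-2-yl or a 1-methyl-1H-pyrazol-3-yl, would behave in the same way. They also leave open what a simple amine or a carboxylic acid on this chain would do.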